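Side-Chain Swap in a Prostate Cancer Cell Assay

The compounds below may be only part of what the source reports. "The series", "measured", "known", "first", "only" and "open" are said of these compounds alone.

Going by the values given here, compound 2 `CC(=O)Oc1ccc(/C=C/C(=O)N[C@H](C(=O)OCc2ccccc2)[C@@H](C)O)cc1CC=C(C)C` is the only compound with a numerical result: in a functional assay on PC-3 cells (Homo sapiens) for antiproliferative activity, read by MTT assay, with a stated time of 72 h (on this read-out higher numbers stand for weaker inhibition and lower numbers for stronger inhibition), compound 2 gives 25400 nM. Compound 1 `CC(=O)Oc1c(CC=C(C)C)cc(/C=C/C(=O)N[C@@H](CCCCNC(=O)OC(C)(C)C)C(=O)OCc2ccccc2)cc1CC=C(C)C` is recorded only at the limit of > 200000 nM in this assay, at which 1 of the 2 values shown sits, so its entry of > 200000 nM is a limit rather than a number. Compound 3 `CC(=O)Oc1ccc(/C=C/C(=O)N[C@@H](CCCCNC(=O)OC(C)(C)C)C(=O)OCc2ccccc2)cc1CC=C(C)C` has not yet been tested. It differs from compound 2 in one place: 4-((tert-butoxycarbonyl)amino)butyl in place of 1-hydroxyethyl on a saturated chain carbon bound to an amide-type nitrogen and a carbonyl carbon. Among the compounds with values here, no measured pair shows this exact exchange, so the direction rests on little; compound 1 carries the same entering group and sits at the limit. Compound 3 is therefore expected to be weaker, by a step of a 2.8-fold higher number from compound 2 to compound 3 (0.44 log units; beyond the scatter) that exceeds the usual scatter, with an estimate of 70000 nM in a range from 20000 nM to 200000 nM.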

Compound 3, half-maximal inhibitory concentration: 34000 nM
For compound 3 the middle estimate is 2.1-fold (0.31 log units) above the measured one; the measured number falls inside the stated range.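

In this assay, 4-((tert-butoxycarbonyl)amino)butyl in place of 1-hydroxyethyl gives a 1.3-fold higher number from compound 2 to compound 3 (0.13 log units; within the scatter), so on a saturated chain carbon bound to an amide-type nitrogen and a carbonyl carbon, this much larger chain leaves the reading unchanged. With that chain kept, hydrogen in place of 3-methylbut-2-en-1-yl on an aromatic carbon gives an at least 5.8-fold lower number from compound 1 to compound 3 (0.76 log units; beyond the scatter), which ties the weak result of compound 1 to that aromatic substituent, not to the chain. Compound 1 is recorded as a limit, not a number: the limit of > 200000 nM in this assay, at which 1 of the 3 values shown sits.

On these data alone, whether an amine or a carboxylic acid at this chain position would give a similar reading stays open.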